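Aryl to cyclohexyl on the amine of the shared core

The compounds below may be only part of what the source reports. "The series", "measured", "known", "first", "only" and "open" are said of these compounds alone.

In a functional assay on MGC-803 cells (Homo sapiens) for inhibition, read by sulforhodamine B assay (on this read-out higher numbers stand for weaker inhibition and lower numbers for stronger inhibition), compound 1 `COc1ccccc1NC1=CC(=O)c2c(nc3n2[C@H]2OC[C@@H](O)[C@H]2OC3)C1=O` gives 1670 nM. Compound 2 `COc1ccc(NC2=CC(=O)c3nc4n(c3C2=O)[C@H]2OC[C@@H](O)[C@H]2OC4)cc1` gives 1680 nM in this assay, a number that sits within the scatter of compound 1, so the two aryl substituents on the amine nitrogen cannot be told apart. Compound 3 `O=C1C(NC2CCCCC2)=CC(=O)c2c1nc1n2[C@H]2OC[C@@H](O)[C@H]2OC1` carries the change (cyclohexyl in place of 2-methoxyphenyl on an amine nitrogen). Going by the values given here, no measured pair covers this kind of change, so only a modest step is expected, in the direction of weaker inhibition, and it may well stay within the scatter: a 1.5-fold higher number from compound 1 to compound 3 (0.18 log units; within the scatter). For compound 3 the expected value in this assay is 2500 nM, with a range from 800 nM to 8000 nM.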

Compound 3, half-maximal inhibitory concentration: > 8000 nM
Compound 3: a limit, no number (the forecaster's own chance of this, stated with the estimate: 5%); middle value at least 3.2-fold (0.50 log units) away from the limit.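

On the amine nitrogen, cyclohexyl in place of 2-methoxyphenyl gives an at least 4.7-fold higher number from compound 1 to compound 3 (0.68 log units; beyond the scatter) in this assay, so this position does respond to the group it carries, although compound 1 and compound 2 could not be told apart. Compound 3 reads > 8000 nM, a limit of the assay and not a number. The true size of the step therefore stays unknown, with only its lower bound fixed: the limit of > 8000 nM in this assay, at which 1 of the 3 values shown sits.

The compounds shown do not separate the loss of the aromatic ring from the loss of the methoxy group. A plain phenyl or a benzyl on the same amine nitrogen would bear on that question.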